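The source may hold more compounds than are shown below. What is called first, only, known or untested is meant among the compounds shown, and "the series" means these compounds.

Measured compounds in a physicochemical assay for solubility; a higher number here means a more soluble compound, a lower number a less soluble compound:
compound 1, `CNC(=O)c1cc(C(=O)NC2CC2)cn(Cc2cccc(OC)c2)c1=O`, 79 ug/mL
compound 2, `CNC(=O)c1cc(C(=O)NC2CCC2)cn(Cc2cccc(NC)c2)c1=O`, >= 155 ug/mL
compound 3, `CNC(=O)c1cccn(Cc2ccccc2)c1=O`, 78 ug/mL

Working notes on the series. Of the two plain numbers in this assay, compound 1 gives the higher one, but compound 3 sits so close that the two are indistinguishable within the scatter of repeat measurements. For the measured compounds named here, the value of compound 2 is a limit of the assay and not a number, and compound 2 is the one compound whose result stands at the limit of >= 155 ug/mL in this assay, at which 1 of the 3 values shown sits. Going by the values given here, no step between two measured compounds is available, so the effect of any single change has to be judged from the structures alone.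

Compound 4, `CNC(=O)c1cc(C(=O)NC2CC2)cn(Cc2cccc3c2CCN3)c1=O`, has not yet been measured in this assay. It differs from compound 1 as follows: 2,3-dihydro-1H-indol-4-yl in place of 3-methoxyphenyl on a saturated chain carbon bound to an aromatic nitrogen.

Expectation for this assay: with no measured step to lean on, only a modest move is expected, and it is expected upward rather than downward, likely near the edge of the scatter. For compound 4 the estimated step from compound 1 is a 1.4-fold higher number from compound 1 to compound 4 (0.14 log units; within the scatter). Compound 4 is thus expected to give about 110 ug/mL in this assay, with a plausible range from 50 ug/mL to 240 ug/mL, and a real chance that the assay returns only a limit.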

Compound 4, solubility: >= 184 ug/mL
Compound 4 ended at the assay's limit; the forecaster's own chance of this, stated with the estimate: 25%; middle value at least 1.6-fold (0.22 log units) away from the limit.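

In this assay, for the compounds shown here, the one step that can be read at this position, on a saturated chain carbon bound to an aromatic nitrogen, is an at least 2.3-fold higher number from compound 1 to compound 4 (0.36 log units; beyond the scatter), for 2,3-dihydro-1H-indol-4-yl in place of 3-methoxyphenyl, and it lies beyond the scatter. The result for compound 4 is a limit of the assay and not a number: the limit of >= 184 ug/mL in this assay, at which 1 of the 4 values shown sits.

The step therefore fixes only a lower bound, and its full size cannot be read from this pair.

The change swaps the methoxy group for a five-membered non-aromatic ring that carries a hydrogen-bond donor, and this single pair cannot separate the contribution of the ring from that of the donor. Going by these compounds, a dihydrobenzofuranyl group, with oxygen in place of the nitrogen of that ring, would be a direct test on the same core, and whether the step holds with a cyclobutyl amide or on the core of compound 3 remains open.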